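A few compounds are considered here, and "the series" means these few. Any claim that something is new, unique, unknown or untested is made for them only; others in the source may bear on it.

Measured so far in an ADME assay on Vero cells (Chlorocebus sabaeus) for cytotoxicity, read by MTT assay, with a stated time of 72 h; on this read-out lower numbers stand for higher toxicity in this test and higher numbers for lower toxicity in this test:

Compound 1, `OC1(c2nnc(-c3ccccc3)[nH]2)CCCCC1`: 422 ug/mL
Compound 2, `OC1(c2nnc(-c3ccncc3)[nH]2)CCCCC1`: 412 ug/mL
Compound 3, `OC(c1nnc(-c2ccccc2)[nH]1)C1CC=CCC1`: 358 ug/mL

The three numbers sit close together, and no ordering among them can be read from this assay. Compound 1 and compound 2 share a core and differ by pyridin-4-yl in place of phenyl on an aromatic carbon; this change gave a 1.0-fold lower number from compound 1 to compound 2 (0.01 log units; within the scatter). Compound 3 carries a different core; the difference between the two cores is not broken down here.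

Compound 4, `OC(c1nnc(-c2ccncc2)[nH]1)C1CC=CCC1`, is not yet measured. It differs from compound 3 by pyridin-4-yl in place of phenyl on an aromatic carbon. This is the same kind of change as that from compound 1 to compound 2, though not the same: around the place, the ring atom bears a group of 8 heavy atoms in compound 3 and compound 4, against a group of 7 heavy atoms in compound 1 and compound 2.

Because the earlier step of a 1.0-fold lower number from compound 1 to compound 2 (0.01 log units; within the scatter) stayed within the scatter, the step of a 1.0-fold lower number from compound 3 to compound 4 (0.01 log units; within the scatter) is expected to do the same. Compound 4 is therefore estimated at 350 ug/mL in this assay, with a range from 240 ug/mL to 500 ug/mL.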

Compound 4, half-maximal cytotoxic concentration: 388 ug/mL
Beside the measured number, compound 4's estimate is 1.1-fold (0.04 log units) below it; low and high end bracket the measured number.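

In this assay, pyridin-4-yl in place of phenyl on an aromatic carbon gave a 1.1-fold higher number from compound 3 to compound 4 (0.03 log units; within the scatter), and the step on the core of compound 1 stands close to it: the same change on two cores in this assay, a 1.0-fold lower number (0.01 log units; within the scatter) from compound 1 to compound 2 and a 1.1-fold higher number (0.03 log units; within the scatter) from compound 3 to compound 4, 1.1-fold (0.05 log units) apart, within the scatter of two such steps. On these two cores, then, the change carries over in a limited sense: it leaves the number within the scatter on both, and the two steps cannot be told apart. This does not fix a direction or size for the change, and two cores do not show that it would stay within the scatter on a further core or in any other read-out.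

The compounds shown hold only phenyl and pyridin-4-yl at this place, so an amine, a carboxylic acid or a longer alkyl chain there remains open. Also open, from the compounds shown here alone, is how the same change would behave in this assay on a core without the hydroxyl group.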